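Adding propyl to the chain of compound 2

This account rests on a few compounds, and the source may have more. Where it says the series, first, only, none or still open, it means among the compounds named here.

Compound 1 (`CCCCCCC(CCO)n1cnc2c(OC)ncnc21`) gives > 50000 nM in a functional assay on SW480 cells (Homo sapiens) for antiproliferative activity, read by MTT assay, with a stated time of 48 h (on this read-out higher numbers stand for weaker inhibition and lower numbers for stronger inhibition), which is a limit and not a number. Compound 2 (`CCCCCCC(CCO)n1cnc2c(N(C)C)ncnc21`) gives > 50000 nM in this assay, also a limit. Compound 3 (`CCCCCCC(CCO)n1cnc2cncnc21`) gives > 50000 nM, again a limit. Compound 2 therefore has no number of its own and stands with the other two at the limit of > 50000 nM in this assay, at which 3 of the 3 values shown sit.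

The change leading to compound 4 (`CCCCCCCCCC(CCO)n1cnc2c(N(C)C)ncnc21`) is propyl in place of hydrogen on a saturated chain carbon, seven bonds along the chain from an aromatic nitrogen, which lengthens the chain from hexyl to nonyl. The measured steps bear on it only weakly. They are a step that the two limits leave unreadable from compound 1 to compound 2, a step that the two limits leave unreadable from compound 1 to compound 3 and a step that the two limits leave unreadable from compound 2 to compound 3. All three exchange a group on an aromatic carbon and none touches the chain, so they offer no size to carry over. Compound 2 sits at a limit, which leaves stronger inhibition as the only direction in which a readable change could appear, and a further limit remains quite possible. The expected change, a loosely held estimate, is an at least 1.4-fold lower number from compound 2 to compound 4 (0.15 log units; that floor lies within the scatter). For compound 4 the estimated value is 35000 nM, with an expected range from 12000 nM to 70000 nM.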

Compound 4, half-maximal inhibitory concentration: 12200 nM
For compound 4 the middle estimate is 2.9-fold (0.46 log units) above the measured one; low and high end bracket the measured number.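

In this assay, propyl in place of hydrogen on a saturated chain carbon, seven bonds along the chain from an aromatic nitrogen, gives an at least 4.0-fold lower number from compound 2 to compound 4 (0.61 log units; beyond the scatter). The earlier steps all exchange a group on an aromatic carbon and cannot be read, so this change to the chain is the first in the series with a readable direction and a lower bound on its size, and compound 4 is the only compound shown with a number rather than a limit: the limit of > 50000 nM in this assay, at which 3 of the 4 values shown sit. Compound 2 has only a limit, so the step gives a floor and not an exact size, and it shows that lengthening the chain from hexyl to nonyl can bring this series into the measurable range of the assay.

The compounds shown leave open whether the effect keeps growing with a longer chain, or whether a shorter extension such as ethyl would already give a readable value. They also leave open whether methoxy or hydrogen in place of dimethylamino would matter once the chain is nonyl, and whether an amine or a carboxylic acid in place of the chain's hydroxyl would keep the gain.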